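The compounds below may be only part of what the source reports. "The series", "measured", "known", "first", "only" and "open" are said of these compounds alone.

Compound 1 `Cc1csc(NC(=O)c2cc(C(C)(C)C)nn2Cc2ccccc2)n1` is the reference point of this set. In a physicochemical assay for lipophilicity, read by HPLC, at pH 7.4 (on this read-out lower numbers stand for lower lipophilicity and higher numbers for higher lipophilicity), compound 1 gives 4.7. Compound 2 `CC(C)(C)c1cc(C(=O)Nc2ccccc2)n(Cc2ccccc2)n1` gives 4.7, and compound 3 `CC(C)(C)c1cc(C(=O)Nc2cccnc2)n(Cc2ccccc2)n1` gives 3.8. Compound 1 therefore stands level with compound 2, the two together at the high end of the three numbers, with compound 3 the furthest from it. The three steps that connect them all change the group on the amide-type nitrogen: no change at the digits printed from compound 1 to compound 2 (within the scatter), a number 0.90 log units lower from compound 1 to compound 3 (beyond the scatter), and a number 0.90 log units lower from compound 2 to compound 3 (beyond the scatter).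

Compound 4 `CC(=O)NCc1csc(NC(=O)c2cc(C(C)(C)C)nn2Cc2ccccc2)n1` differs from compound 1 in one place: acetamido in place of hydrogen on a saturated chain carbon bound to an aromatic carbon. Among the compounds with values here, no measured step touches this position, so none bears directly on it. Within the data shown here, the only guidance is indirect: the one step that brings a hydrogen-bond acceptor into the amide-type substituent, from compound 1 to compound 3, lowered this assay by a modest amount, while the swap of phenyl for 4-methyl-1,3-thiazol-2-yl left it unchanged. Acetamido brings both a donor and an acceptor, so a downward step of similar or somewhat larger size is expected, with wide uncertainty. Compound 4 is estimated at 3.6 in this assay, within 3 to 4.2, which means an expected step of a number 1.10 log units lower from compound 1 to compound 4 (beyond the scatter).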

Compound 4, distribution coefficient: 3.3
The estimate for compound 4 lay 0.30 log units above the measured number; measured number inside the range.
By their numbers in this assay, from the lowest: compound 4; then compound 3; then compounds 1 and 2 (each within the scatter of the next).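

Within the data shown here, the saturated chain carbon bound to an aromatic carbon, a place no earlier step touched, proves responsive in this assay: acetamido in place of hydrogen there gives a number 1.40 log units lower from compound 1 to compound 4 (beyond the scatter). Read as methyl to acetamidomethyl, this change on the 4-methyl-1,3-thiazol-2-yl group counts as a large step, whereas replacing that whole group gives the modest a number 0.90 log units lower from compound 1 to compound 3 (beyond the scatter) with pyridin-3-yl and no change at the digits printed from compound 1 to compound 2 (within the scatter) with phenyl. Nothing at hand gives a measured reason for the size of the new step.

The compounds shown leave open which part of acetamidomethyl carries the step, since a simple amine, a hydroxyl, a carboxylic acid or a longer chain on the same carbon would each separate the contribution of the carbonyl and the amide hydrogen from that of the added chain. They also leave open whether acetamidomethyl on the phenyl of compound 2 or the pyridin-3-yl of compound 3 would give a step of the same size, or whether this step belongs to the 4-methyl-1,3-thiazol-2-yl series alone.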